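Z to E at the double bond of compound 1

The compounds below may be only part of what the source reports. "The series", "measured", "known", "first", "only" and "open" are said of these compounds alone.

In a functional assay on M21 cells (Homo sapiens) for inhibition, read by sulforhodamine B assay, with a stated time of 48 h (on this read-out higher numbers stand for weaker inhibition and lower numbers for stronger inhibition), compound 1 `CCNC(=O)Nc1ccc(/C=C\c2cc(C)cc(C)c2)cc1` gives 16000 nM and compound 2 `CCNC(=O)Nc1ccc(/C=C/c2cc(OC)c(OC)c(OC)c2)cc1` gives 29000 nM as its value, two numbers within the scatter of each other. Compound 3 `O=C1NCCN1c1ccc(/C=C\c2cccc(Cl)c2)cc1` gives 27 nM in the same read-out, a far lower number that lies beyond the scatter from compound 1. Compound 1 therefore stands with compound 2 at the weak end of the three measured compounds.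

The next compound is compound 4 `CCNC(=O)Nc1ccc(/C=C/c2cc(C)cc(C)c2)cc1` and the change is the two compounds have the same atoms and bonds and differ only in configuration as drawn: 1 of 1 stereo elements differ; a double bond is drawn Z in compound 1 and E in compound 4 with nothing else altered: a double bond is drawn Z in compound 1 and E in compound 4. Within the data shown here, no measured pair isolates this change. Among the measured compounds shown here, compound 2 is the only measured compound drawn E, and its ring groups differ from those of compound 4.

In this assay the expected 1.8-fold higher number from compound 1 to compound 4 (0.24 log units; within the scatter) is small, toward a higher number, and may well stay within the scatter. For compound 4 the estimated value is 28000 nM with an expected span from 9000 nM to 90000 nM as the working range.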

Compound 4, half-maximal inhibitory concentration: > 20000 nM
Compound 4: only a limit was reported; the forecaster's own chance of this, stated with the estimate: 20%; the middle value lies beyond the limit too.
By their numbers in this assay, from the lowest: compound 3; then compounds 1 and 2 (each within the scatter of the next).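

Compound 4 gives > 20000 nM in this assay, and this is a limit of the assay and not a number. Among these compounds, for the first time, the double bond has a comparison in which nothing else varies, and it reads as an at least 1.2-fold higher number from compound 1 to compound 4 (0.09 log units; that floor lies within the scatter). Drawn E at this position, the compound shows no sign of stronger inhibition than compound 1, but the size of any loss stays unknown, and the floor of the step does not separate the two compounds.

Still open, as far as these compounds go, is whether the same change from Z to E carries over to compound 3, whose far lower number of 27 nM sits on a compound that differs from compound 1 in more than one place. Also open, from the compounds shown here alone, is what this change does in a compound carrying an amine or a hydroxyl group.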